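Swapping anilino for propyl on the carbamoyl nitrogen

The source may report more compounds than this note shows. Statements on the series, on what has been measured and on what is new or still open speak of the compounds shown alone.

Measured compounds:
Compound 1, `CN1CCN(C(=O)c2c(NC(=O)NS(=O)(=O)c3ccccc3)sc3c2CCCCC3)CC1`: 22300 nM
Compound 2, `CCCCNC(=O)c1c(NC(=O)NS(=O)(=O)c2ccccc2)sc2c1CCCCC2`: 30300 nM
Compound 3, `O=C(Nc1sc2c(c1C(=O)NNc1ccccc1)CCCCC2)NS(=O)(=O)c1ccccc1`: 16000 nM

All three values come from a functional assay on NSCLC cells (Homo sapiens) for inhibition, with a stated time of 48 h; a lower number here means a stronger inhibitor of growth, a higher number a weaker inhibitor of growth. Compound 3 shows the lowest of the three numbers, but the gaps are small: a 1.4-fold lower number from compound 1 to compound 3 (0.14 log units; within the scatter) and a 1.9-fold lower number from compound 2 to compound 3 (0.28 log units; within the scatter), both within the scatter. Compound 4, `CCCNC(=O)c1c(NC(=O)NS(=O)(=O)c2ccccc2)sc2c1CCCCC2`, differs from compound 3 in one place: propyl in place of anilino on an amide-type nitrogen. Among the compounds with values here, the only measured step that bears on this is the one from compound 2 to compound 3, where butyl gave way to anilino: a 1.9-fold lower number from compound 2 to compound 3 (0.28 log units; within the scatter). Compound 4 reverses that change, with a chain one carbon shorter than in compound 2, so a number close to that of compound 2 is expected, a step of a 1.7-fold higher number from compound 3 to compound 4 (0.23 log units; within the scatter) at most, not beyond the scatter. Compound 4 is therefore estimated at 27000 nM, within 12000 nM to 60000 nM.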

Compound 4, concentration for 50% growth inhibition: 54200 nM
The estimate for compound 4 lay 2.0-fold (0.30 log units) below the measured number; measured number inside the range.
By their numbers in this assay, from the lowest: compounds 3, 1, 2 and 4 (each within the scatter of the next, the first and the last beyond it).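

Here, for the first time, a change on the amide-type nitrogen moves the number beyond the scatter: propyl in place of anilino gives a 3.4-fold higher number from compound 3 to compound 4 (0.53 log units; beyond the scatter). Propylamino in place of 4-methylpiperazin-1-yl also passes the scatter, with a 2.4-fold higher number from compound 1 to compound 4 (0.39 log units; beyond the scatter), whereas propyl in place of butyl stays within it, with a 1.8-fold higher number from compound 2 to compound 4 (0.25 log units; within the scatter). No measurement at hand gives a reason for these steps.

Still open, on these data alone, is whether a benzyl group on that nitrogen would read like anilino or like propyl. Also open, as far as these compounds go, is how a longer chain such as hexyl, or a chain ending in a carboxylic acid, would read.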